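The source may report more compounds than this note shows. Statements on the series, on what has been measured and on what is new or still open speak of the compounds shown alone.

Three compounds have been measured in a functional assay on GOTO cells (Homo sapiens) for cytotoxicity, read by MTT assay, with a stated time of 3 days; on this read-out lower numbers stand for stronger inhibition and higher numbers for weaker inhibition:

Compound 1 `N#Cc1c(Nc2ccccc2)nc(SCc2nc3ccccc3[nH]2)nc1-c1ccccc1`: 6.41 nM
Compound 2 `CCNc1nc(SCc2nc3ccccc3[nH]2)nc(-c2ccccc2)c1C#N`: 3.96 nM
Compound 3 `N#Cc1c(Nc2ccccn2)nc(SCc2nc3ccccc3[nH]2)nc1-c1ccccc1`: 2.5 nM

Compound 1 holds the highest of the three numbers. The nearest number lies at a 1.6-fold lower number from compound 1 to compound 2 (0.21 log units; within the scatter), and the furthest at a 2.6-fold lower number from compound 1 to compound 3 (0.41 log units; beyond the scatter).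

The unmeasured compound 4 `N#Cc1c(Nc2nccs2)nc(SCc2nc3ccccc3[nH]2)nc1-c1ccccc1` departs from compound 1 by one change: 1,3-thiazol-2-yl in place of phenyl on a nitrogen on an aromatic ring.

Among the measured compounds shown here, the closest precedent is a 2.6-fold lower number from compound 1 to compound 3 (0.41 log units; beyond the scatter), a modest step, where pyridin-2-yl replaces the same phenyl. The other two steps at this place, a 1.6-fold lower number from compound 1 to compound 2 (0.21 log units; within the scatter) and a 1.6-fold lower number from compound 2 to compound 3 (0.20 log units; within the scatter), show that the three groups tested there stay close together. A modest move towards a lower number is therefore expected in this assay, of a size near the edge of the scatter.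

The expected change is a 2.0-fold lower number from compound 1 to compound 4 (0.30 log units; within the scatter).

For compound 4 the estimated value is 3.2 nM, with an expected range from 1.3 nM to 8 nM.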

Compound 4, half-maximal inhibitory concentration: 5.1 nM
Compound 4: the middle estimate sits 1.6-fold (0.20 log units) below what was measured, within the range that was stated.
By their numbers in this assay, from the lowest: compounds 3, 2, 4 and 1 (each within the scatter of the next, the first and the last beyond it).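

In this assay, replacing phenyl with 1,3-thiazol-2-yl on this nitrogen leaves the number within the scatter (a 1.3-fold lower number from compound 1 to compound 4 (0.10 log units; within the scatter)), and the same holds for the change from ethyl (a 1.3-fold higher number from compound 2 to compound 4 (0.11 log units; within the scatter)), so this five-membered aromatic ring with 2 hetero atoms cannot be told apart from either group. Among the compounds shown here, the one step beyond the scatter is modest and separates the two hetero-aromatic groups (a 2.0-fold higher number from compound 3 to compound 4 (0.31 log units; beyond the scatter)), which shows that the lower number seen with pyridin-2-yl does not extend to every aromatic ring containing a hetero atom, with compound 4 going against any such rule. No available evidence explains this difference between the two rings.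

The compounds shown leave open how a morpholine, a carboxylic acid or a longer alkyl chain on this nitrogen would compare. They also leave open whether an amide in place of the nitrile would alter the small differences seen here.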